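This account rests on a few compounds, and the source may have more. Where it says the series, first, only, none or still open, it means among the compounds named here.

Three compounds built on the shared core were examined in an ADME assay on HCT-116 cells (Homo sapiens) for cytotoxicity, read by CellTiter-Glo, with a stated time of 72 h; a higher number here means a weaker inhibitor, a lower number a stronger inhibitor. Compound 1 `CC1CCN(C2CCN(S(=O)(=O)c3cccc4ccccc34)CC2)CC1` returns only a limit of the assay, > 10000 nM. Compound 2 `CC1CCN(C2CCN(S(=O)(=O)c3cccnc3)CC2)CC1` likewise returns only a limit, > 10000 nM. Compound 3 `Cc1cc(C)c(S(=O)(=O)N2CCC(N3CCC(Cc4ccc(F)cc4)CC3)CC2)c(C)c1` also yields no number but a limit, > 5000 nM. Compound 2 therefore stands at the limit of > 10000 nM in this assay, at which 2 of the 3 values shown sit. Compound 3 sits at the limit of > 5000 nM in this assay, at which 1 of the 3 values shown sits. Compound 4 `CC1CCN(C2CCN(S(=O)(=O)c3cccc(Br)c3)CC2)CC1` has not yet been measured in this assay; it differs from compound 2 by 3-bromophenyl in place of pyridin-3-yl on a sulfonyl sulfur. Among the measured compounds shown here, no step between measured compounds is available to guide the estimate. Compound 4 is expected to show no step beyond the scatter, a step that the limit leaves unreadable from compound 2 to compound 4. Compound 4 is thus estimated at 15000 nM, with a range from 5000 nM to 50000 nM.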

Compound 4, half-maximal inhibitory concentration: > 5000 nM
Compound 4: a limit, no number; the forecaster's own chance of this, stated with the estimate: 85%; the middle value is on the limit's open side.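

Compound 2 and compound 4 both return only limits in this assay, so no step can be read between them. The compounds shown leave open whether 3-bromophenyl in place of pyridin-3-yl on the sulfonyl sulfur changes the result at all.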